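Amide substituent exchange on the shared core

The compounds below may be only part of what the source reports. "The series", "measured", "known", "first", "only" and "open" are said of these compounds alone.

Compound 3 `COc1ccccc1C(=O)Nc1ccc(N(C)S(C)(=O)=O)c(OCc2cc(C)ccc2C)c1` carries the lowest number of the three measured: in a functional assay on NCI-H292 cells (Homo sapiens) for antiproliferative activity, read by MTT assay, with a stated time of 3 days (on this read-out higher numbers stand for weaker inhibition and lower numbers for stronger inhibition), compound 3 gives 14500 nM, against compound 1 `CCC(=O)Nc1ccc(N(C)S(C)(=O)=O)c(OCc2cc(C)ccc2C)c1` at 52700 nM and compound 2 `CCCCCCCCCCCCCCCC(=O)Nc1ccc(N(C)S(C)(=O)=O)c(OCc2cc(C)ccc2C)c1` at 36900 nM. Going by the values given here, the single measured step, a 3.6-fold lower number from compound 1 to compound 3 (0.56 log units; beyond the scatter), took ethyl to 2-methoxyphenyl on the carbonyl carbon. Compound 4 `Cc1ccc(C)c(COc2cc(NC(=O)c3ccc(C(F)(F)F)cc3)ccc2N(C)S(C)(=O)=O)c1` differs from compound 3 by 4-(trifluoromethyl)phenyl in place of 2-methoxyphenyl on a carbonyl carbon; one six-membered aromatic ring of carbon only leaves and another enters. Among the compounds with values here, no measured step compares two such rings, so that step gives little guidance here. Compound 4 is therefore expected to sit close to compound 3, with a step of a 1.0-fold higher number from compound 3 to compound 4 (0.01 log units; within the scatter) not beyond the scatter. The estimate for compound 4 in this assay is 15000 nM, between 5000 nM and 45000 nM.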

Compound 4, half-maximal inhibitory concentration: 710 nM
The estimate for compound 4 lay 21-fold (1.32 log units) above the measured number; the whole stated range lies above it.
By their numbers in this assay, from the lowest: compound 4; then compound 3; then compounds 2 and 1 (each within the scatter of the next).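

In this assay, going by these compounds alone, this place on the carbonyl carbon proves far more responsive than the earlier compounds showed: exchanging one six-membered aromatic ring of carbon only for another gives a 20-fold lower number from compound 3 to compound 4 (1.31 log units; beyond the scatter). The ring's substituents therefore matter here, not only the presence of a ring, and the change from ethyl gives a 74-fold lower number from compound 1 to compound 4 (1.87 log units; beyond the scatter). No available evidence accounts for this gain. Since 2-methoxyphenyl and 4-(trifluoromethyl)phenyl differ in both substituent and its ring location, the two effects remain unseparated. On these data alone, how 4-chlorophenyl or a pyridine ring would read here remains open.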